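This account rests on a few compounds, and the source may have more. Where it says the series, first, only, none or still open, it means among the compounds named here.

Series notes, core shared by all members.

Compound 1 `CCOC(=O)c1c(N)sc(/N=C/c2ccccc2)c1C(=O)OCC` is the reference. Among the measured compounds shown here, in a functional assay on Ishikawa cells (Homo sapiens) for inhibition, read by MTT assay, with a stated time of 48 h (a higher number here means a weaker inhibitor, a lower number a stronger inhibitor), compound 1 gives 37900 nM, the lower of the two numbers measured so far, though its nearest neighbour lies within the scatter. Compound 2 `CCOC(=O)c1c(N)sc(/N=C/c2ccc(N(C)C)cc2)c1C(=O)OCC` carries a dimethylamino in place of hydrogen on an aromatic carbon; in this assay compound 2 gives 73000 nM. For the measured compounds named here, the only measured step, a 1.9-fold higher number from compound 1 to compound 2 (0.28 log units; within the scatter), shows that a substituent added to that aromatic ring moved the read-out no further than repeat measurements would.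

Compound 3 `CCOC(=O)c1c(N)sc(/N=C/c2ccncc2)c1C(=O)OCC` is not yet measured. It differs from compound 1 as follows: pyridin-4-yl in place of phenyl on a carbon with a double bond to nitrogen. Going by the values given here, no measured step exchanges a ring atom of this aromatic ring, so the step from compound 1 to compound 2 bears on it only loosely, as a sign that alterations at this ring have so far stayed inside the scatter. On that basis the step from compound 1 to compound 3 is expected to be a 1.1-fold higher number from compound 1 to compound 3 (0.02 log units; within the scatter), that is, no change beyond the scatter in either direction. For compound 3 the estimated read-out is 40000 nM, with a range from 15000 nM to 110000 nM.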

Compound 3, half-maximal inhibitory concentration: 119000 nM
For compound 3 the middle estimate is 3.0-fold (0.47 log units) below the measured one; measured number above the stated range.
By their numbers in this assay, from the lowest: compounds 1, 2 and 3 (each within the scatter of the next, the first and the last beyond it).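

In this assay, among the compounds shown here, the exchange of phenyl for pyridin-4-yl on a carbon with a double bond to nitrogen gives a 3.1-fold higher number from compound 1 to compound 3 (0.50 log units; beyond the scatter) and is the first step to pass the scatter; it is a modest step, and it differs in kind from the earlier one, since a ring carbon gives way to a ring nitrogen and one hydrogen-bond acceptor enters, with no substituent added to the ring. For the compounds shown here, the same place read against the dimethylamino compound gives a 1.6-fold higher number from compound 2 to compound 3 (0.21 log units; within the scatter) and stays within the scatter, so pyridin-4-yl and 4-(dimethylamino)phenyl are not separated here, and only the pair of compound 1 and compound 3 stands apart. Nothing measured on these compounds accounts for the step, which therefore stands as an observation only.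

The compounds shown leave open whether pyridin-3-yl or pyridin-2-yl at this place would read like compound 3 or like compound 1, so the weight of the ring nitrogen's location is unknown. They also leave open how far the read-out depends on the ethyl esters and the free amine of the shared core, for example with a carboxylic acid or an amide in place of an ester.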